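The source may report more compounds than this note shows. Statements on the series, on what has been measured and on what is new or still open speak of the compounds shown alone.

Compound 2 `COc1ccc2c(/C=C/C(=O)c3cc(N)c(OC)c(OC)c3)c[nH]c2c1` gives the lowest of the three numbers in a functional assay on MHCC97H cells (Homo sapiens) for antiproliferative activity, read by MTT assay, with a stated time of 48 h; a higher number here means a weaker inhibitor, a lower number a stronger inhibitor: in this assay compound 2 gives 186 nM. Its nearest neighbour is compound 1 `COc1ccc2c(/C=C/C(=O)c3cc(N)c(OC)c(OC)c3)cn(C)c2c1`, which in this assay gives 198 nM; the two differ only by hydrogen in place of methyl on an aromatic nitrogen, and the step of a 1.1-fold lower number from compound 1 to compound 2 (0.03 log units; within the scatter) lies within the scatter, so no order can be claimed between them. The third compound, compound 3 `COc1cc(C(=O)/C=C/c2cn(C)c3ccccc23)cc([N+](=O)[O-])c1OC`, in this assay gives 850 nM, a number beyond the scatter from compound 2, but compound 3 differs from compound 2 in more than one place, so its value shows only where it stands, not what any single change does.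

Compound 4 `COc1ccc2c(/C=C/C(=O)c3cc(OC)c(OC)c([Se]C)c3)c[nH]c2c1` is the untested member. Relative to compound 2 the difference is a group of 2 heavy atoms (1 carbon, 1 selenium; no ring) in place of one nitrogen atom, on an aromatic carbon. Within the data shown here, no measured step here concerns this position or either of the groups involved: the only step measured, from compound 1 to compound 2, touches the aromatic nitrogen and lies within the scatter. The expectation for compound 4 in this assay therefore rests on weak ground, and the estimated step of a 1.6-fold higher number from compound 2 to compound 4 (0.21 log units; within the scatter) is set near zero with a wide range. Compound 4 is thus estimated at 300 nM, between 80 nM and 1500 nM.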

Compound 4, half-maximal inhibitory concentration: 58 nM
Estimate against measurement, compound 4: 5.2-fold (0.71 log units) above, and the stated range ends above it.
By their numbers in this assay, from the lowest: compound 4; then compounds 2 and 1 (each within the scatter of the next); then compound 3.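

In this assay, the aromatic carbon ortho to a methoxy group, which no earlier step had touched, proves responsive: exchanging amino for a group of 2 heavy atoms (1 carbon, 1 selenium) gives a 3.2-fold lower number from compound 2 to compound 4 (0.51 log units; beyond the scatter), the first listed step beyond the scatter between compounds that differ in one place. For this pair, the amino group, with its 1 hydrogen-bond donor and 1 hydrogen-bond acceptor, is not needed to reach a number in this range, since the entering group has 0 hydrogen-bond donors and 0 hydrogen-bond acceptors and compound 4 still gives the lower number. No measurement bearing on the reason for this step is available here.

The compounds shown leave open whether selenium itself matters, since a single pair cannot say how a methylthio group, a hydroxyl group or a plain hydrogen would compare at this position. They also leave open whether exchanging hydrogen for methyl on the aromatic nitrogen would stay within the scatter with the selenium-bearing group in place, as that step is known only with amino present.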